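The source may report more compounds than this note shows. Statements on the series, on what has been measured and on what is new or still open speak of the compounds shown alone.

Measured in a functional assay on NCI-H460 cells (Homo sapiens) for positive allosteric modulation, read by MTT assay, with stated times of 2 h and 72 h, tested at 10 uM; a lower number here means a stronger inhibitor, a higher number a weaker inhibitor:
- compound 1 `COc1cccc(-n2nnc(-c3ccccc3NC(=O)c3ccc(NC(C)=O)cc3)n2)c1` gives 520 nM
- compound 2 `COc1cccc(-n2nnc(-c3ccccc3NC(=O)Nc3ccc([N+](=O)[O-])cc3)n2)c1` gives 113 nM

Compound 2, at 113 nM, holds the lower of the two numbers in this assay. The next structure, compound 3 `COc1cccc(-n2nnc(-c3ccccc3NC(=O)Nc3ccc(N)cc3)n2)c1`, has amino in place of nitro on an aromatic carbon, para to a large group: amino in place of nitro on an aromatic carbon. Among the measured compounds shown here, no measured step makes this exact exchange. For the measured compounds named here, the only step available is a 4.6-fold lower number from compound 1 to compound 2 (0.66 log units; beyond the scatter), a modest one that replaces the whole group on the carbonyl carbon, so it bears on the change only loosely. Compound 1, whose 4-acetamidophenyl group carries nitrogen and no nitro, gives 520 nM, and this points to a modest rise rather than a fall. The expected change is a 2.2-fold higher number from compound 2 to compound 3 (0.34 log units; beyond the scatter), a step of similar or smaller size. For compound 3 the estimated value is 250 nM, with an expected range of 80 nM to 800 nM.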

Compound 3, half-maximal inhibitory concentration: 176 nM
Beside the measured number, compound 3's estimate is 1.4-fold (0.15 log units) above it, within the range that was stated.
By their numbers in this assay, from the lowest: compounds 2 and 3 (each within the scatter of the next); then compound 1.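

In this assay, amino in place of nitro on an aromatic carbon, para to a large group, gives a 1.6-fold higher number from compound 2 to compound 3 (0.19 log units; within the scatter), so this exchange does not separate the two compounds, although amino has fewer heavy atoms than nitro and carries a hydrogen-bond donor that nitro lacks. With (4-aminophenyl)amino in place of 4-acetamidophenyl on the carbonyl carbon, the result is a 3.0-fold lower number from compound 1 to compound 3 (0.47 log units; beyond the scatter), a step in the same direction as a 4.6-fold lower number from compound 1 to compound 2 (0.66 log units; beyond the scatter), which shows that the lower number seen with the (4-nitrophenyl)amino group does not require nitro. The data offer no measured explanation for why amino and nitro read alike at this position.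

Going by these compounds, what a carboxylic acid or a dimethylamino group would do on the same aromatic carbon remains open. On these data alone, it also remains open whether the same exchange of nitro for amino would read alike at another place on this ring.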